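The source may hold more compounds than are shown below. What is called first, only, known or untested is meant among the compounds shown, and "the series" means these compounds.

Measured in a functional assay on M21 cells (Homo sapiens) for antiproliferative activity, read by sulforhodamine B assay, with a stated time of 48 h; on this read-out lower numbers stand for stronger inhibition and higher numbers for weaker inhibition:
Compound 1 `CN1CCN(c2ccc(S(=O)(=O)Oc3cccc(Br)c3)cc2)C1=O`: 1300 nM
Compound 2 `CCN1CCN(c2ccc(S(=O)(=O)Oc3ccccc3OC)cc2)C1=O`: > 100000 nM (a limit of the assay, not a number)
Compound 3 `CCN1CCN(c2ccc(S(=O)(=O)Oc3cccc(Cl)c3)cc2)C1=O`: 3900 nM

For the measured compounds named here, of the two exact numbers, the one for compound 3, 3900 nM, is the higher, and the gap to compound 1 lies beyond the scatter. Compound 4 `CCN1CCN(c2ccc(S(=O)(=O)Oc3cccc(Br)c3)cc2)C1=O` differs from compound 3 by one swap: bromo in place of chloro on an aromatic carbon. It sits on an aromatic carbon, meta to a large group. Going by the values given here, the only measured step, an at least 25-fold lower number from compound 2 to compound 3 (1.40 log units; beyond the scatter), is large, but it replaces 2-methoxyphenyl, so it says little about exchanging one halogen for another. A closer guide is compound 1, which also carries 3-bromophenyl and gives 1300 nM, although it differs elsewhere too. A small shift towards a lower number is therefore expected, with a 1.6-fold lower number from compound 3 to compound 4 (0.19 log units; within the scatter) as the estimated step. For compound 4 the estimate is 2500 nM, with an expected range of 900 nM to 7000 nM.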

Compound 4, half-maximal inhibitory concentration: 3400 nM
Compound 4: the middle estimate sits 1.4-fold (0.13 log units) below what was measured; the range from low to high includes it.
By their numbers in this assay, from the lowest: compound 1; then compounds 4 and 3 (each within the scatter of the next). At a limit, above all of these: compound 2.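

In this assay, bromo and chloro on this aromatic carbon cannot be told apart: a 1.1-fold lower number from compound 3 to compound 4 (0.06 log units; within the scatter). Set against compound 2, whose reading is a limit of the assay and not a number, 3-bromophenyl stands as far clear as 3-chlorophenyl does: an at least 29-fold lower number from compound 2 to compound 4 (1.46 log units; beyond the scatter). With 3-bromophenyl held fixed, methyl in place of hydrogen on the chain carbon bound to the amide-type nitrogen matters more than the halogen swap: a 2.6-fold higher number from compound 1 to compound 4 (0.42 log units; beyond the scatter).

Still open, as far as these compounds go, is how a nitrile or an amine on this same aromatic carbon would read, since only two halogens appear there. Also open, from the compounds shown here alone, is whether a longer chain on that nitrogen would continue the shift seen with methyl.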